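The source may report more compounds than this note shows. Statements on the series, on what has been measured and on what is new or still open speak of the compounds shown alone.

Of the compounds shown here, three have been measured in a functional assay on A549 cells (Homo sapiens) for antiproliferative activity, read by MTT assay, with a stated time of 48 h; a higher number here means a weaker inhibitor, a lower number a stronger inhibitor. Compound 1 `C=C(c1ccc(OC)cc1NC(=O)CN)c1ccc(OC)c2c1OC(C)(C)C=C2` gives 50 nM in this assay. Compound 3 `C=C(c1ccc(OC)cc1NC(=O)CNC)c1ccc(OC)c2c1OC(C)(C)C=C2` shares the core of compound 1 and differs from it in one place, (methyl in place of hydrogen on an amine nitrogen). In this assay compound 3 gives 150 nM, and the step of a 3.0-fold higher number from compound 1 to compound 3 (0.48 log units; beyond the scatter) lies beyond the scatter of the measurement. Compound 2 `C=C(c1cc(OC)c(OC)c(OC)c1)c1ccc(OC)cc1NC(=O)CN` rests on a different core, and how the two cores differ is not broken down here. In this assay compound 2 gives 40 nM, which stands within the scatter of the value of compound 1 and beyond the scatter from the value of compound 3.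

Compound 4 `C=C(c1cc(OC)c(OC)c(OC)c1)c1ccc(OC)cc1NC(=O)CNC` has not yet been measured in this assay. It stands to compound 2 as compound 3 stands to compound 1: the change is methyl in place of hydrogen on an amine nitrogen. The place of the change is described in the same words for both pairs, an amine nitrogen whose other neighbour is a saturated chain carbon, so it is the same change made on a second core.

The expectation for compound 4 rests on compound 1 and compound 3, whose step a 3.0-fold higher number from compound 1 to compound 3 (0.48 log units; beyond the scatter) was a modest rise in the number, and on compound 2, which gives 40 nM. Compound 4 is therefore expected to give 120 nM in this assay. The estimate for compound 4 is expected to fall between 55 nM and 260 nM. The step this estimate implies is a 3.0-fold higher number from compound 2 to compound 4 (0.48 log units; beyond the scatter), set beside the earlier one.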

Compound 4, half-maximal inhibitory concentration: 100 nM
For compound 4 the middle estimate is 1.2-fold (0.08 log units) above the measured one; low and high end bracket the measured number.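

In this assay, methyl in place of hydrogen on the amine nitrogen again gives a higher number on the second core, with a 2.5-fold higher number from compound 2 to compound 4 (0.40 log units; beyond the scatter), and the two steps do not differ beyond what repeated measurement allows: the same change on two cores in this assay, a 3.0-fold higher number (0.48 log units; beyond the scatter) from compound 1 to compound 3 and a 2.5-fold higher number (0.40 log units; beyond the scatter) from compound 2 to compound 4, 1.2-fold (0.08 log units) apart, within the scatter of two such steps. Across these two pairs, then, the change carries over from one core to the other in both direction and size, and the number measured on one core would have served as a fair guide to the other. Going by these compounds alone, this rests on only two pairs and a single change in one cell assay, so it does not show that the step would hold on any further core, and it does not explain why the methyl group raises the number.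

The compounds shown carry only hydrogen or methyl on this amine nitrogen, so it remains open what a second methyl, an ethyl group or a longer chain would do there. From the compounds shown here alone, it also remains open how the series would respond if the amine itself gave way to a hydroxyl group or a carboxylic acid, and whether such a change would carry between the two cores as closely as methyl does.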